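Five-membered aryl variants on the shared core

The compounds below may be only part of what the source reports. "The series", "measured", "known", "first", "only" and "open" are said of these compounds alone.

Compound 1 `Nc1nc(N)c2c(-c3ccccc3)cn([C@@H]3O[C@H](CO)[C@@H](O)[C@H]3O)c2n1` carries phenyl on the shared core. In a functional assay on HepG2 cells (Homo sapiens) for antiproliferative activity, read by XTT assay, with a stated time of 72 h (a lower number here means a stronger inhibitor, a higher number a weaker inhibitor), compound 1 gives only a limit, > 20000 nM. Compound 2 `COc1nc(N)nc2c1c(-c1ccoc1)cn2[C@@H]1O[C@H](CO)[C@@H](O)[C@H]1O` likewise gives only a limit, > 20000 nM. Compound 3 `Nc1nc(N)c2c(-c3cccs3)cn([C@@H]3O[C@H](CO)[C@@H](O)[C@H]3O)c2n1` also gives only a limit, > 20000 nM. Compound 3 thus stands where every value shown stands, and the step that the two limits leave unreadable from compound 1 to compound 3 cannot be read because of the limit of > 20000 nM in this assay, at which 3 of the 3 values shown sit. Compound 4 `Nc1nc(N)c2c(-c3ccoc3)cn([C@@H]3O[C@H](CO)[C@@H](O)[C@H]3O)c2n1` differs from compound 3 by furan-3-yl in place of thiophen-2-yl on an aromatic carbon. For the measured compounds named here, the one measured step at this position is unreadable, so the only guide is that every value so far sits at the limit, due to the limit of > 20000 nM in this assay, at which 3 of the 3 values shown sit. Compound 4 is therefore expected to stay at the limit as well, with an expected step that the limit leaves unreadable from compound 3 to compound 4. The estimate for compound 4 is 30000 nM, within 12000 nM to 100000 nM.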

Compound 4, half-maximal inhibitory concentration: > 20000 nM
Compound 4: a limit, no number; the forecaster's own chance of this, stated with the estimate: 85%; the middle value does not contradict the limit.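

Compound 4 gives only a limit, like compound 1, compound 2 and compound 3, so no step among these compounds can be read, due to: the limit of > 20000 nM in this assay, at which 4 of the 4 values shown sit.

Going by these compounds, whether any group at this position on the shared core gives a number rather than a limit stays open.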